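Swapping Methyl for Fluoro on an Aryl Tail

The source may report more compounds than this note shows. Statements on the series, on what has been measured and on what is new or still open speak of the compounds shown alone.

Compound 1 `Cc1ccccc1CCCCCCC(=O)N1CCCC1` and compound 2 `Cc1cccc(CCCCCCC(=O)N2CCCC2)c1` are built from the same atoms joined differently; the difference between the two cores is not broken down here. In an assay on HEK293 cells for inhibition of N-acylethanolamine-hydrolyzing acid amidase (Rattus norvegicus), read by LC-MS, with a stated time of 30 min (a lower number here means a stronger inhibitor, a higher number a weaker inhibitor), compound 1 gives 68400 nM, and compound 2 gives 8300 nM. Compound 3 `O=C(CCCCCCc1ccccc1F)N1CCCC1` carries fluoro in place of methyl on an aromatic carbon relative to compound 1, and in this assay compound 3 gives 13700 nM, which amounts to a 5.0-fold lower number from compound 1 to compound 3 (0.70 log units; beyond the scatter). Compound 4 `O=C(CCCCCCc1cccc(F)c1)N1CCCC1` differs from compound 2 by fluoro in place of methyl on an aromatic carbon, the same kind of change, though here the place is meta to a large group rather than ortho to a large group. Because compound 2 already gives 8300 nM, the lowest of the three numbers, a smaller step is expected for compound 4, namely a 1.7-fold lower number from compound 2 to compound 4 (0.22 log units; within the scatter). Compound 4 is therefore expected to give 5000 nM, between 1500 nM and 20000 nM.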

Compound 4, half-maximal inhibitory concentration: 7300 nM
Compound 4: the middle estimate sits 1.5-fold (0.16 log units) below what was measured; low and high end bracket the measured number.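

On the core of compound 2, fluoro in place of methyl amounts to a 1.1-fold lower number from compound 2 to compound 4 (0.06 log units; within the scatter) in this assay, so the swap has no effect there that can be told apart from the scatter. Set beside the earlier step, the same change does not carry over from one core to the other at the same size: the same change on two cores in this assay, a 5.0-fold lower number (0.70 log units; beyond the scatter) from compound 1 to compound 3 and a 1.1-fold lower number (0.06 log units; within the scatter) from compound 2 to compound 4, 4.4-fold (0.64 log units) apart, beyond the scatter of two such steps

This shows that a step seen on one core cannot simply be assumed on the other, but two pairs give no general rule and do not show why the steps differ. On these data alone, it remains open whether chloro or trifluoromethyl in place of the methyl would follow either step. A longer chain on either core might also change the size of the step, and the compounds shown do not settle this.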